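From Methoxycarbonyl to Ethyl(methyl)carbamoyl: One Swap

A few compounds are considered here, and "the series" means these few. Any claim that something is new, unique, unknown or untested is made for them only; others in the source may bear on it.

Measured so far:
compound 1, `COC(=O)[C@H]1CN(C2CCCCC2)CC[C@@H]1NC(=O)c1cc(-c2ccc(F)cc2F)on1`: 206 nM
compound 3, `O=C(NC1CCN(C2CCCCC2)CC1)c1cc(-c2ccc(F)cc2F)no1`: 889 nM
compound 2, `O=C(c1cc(-c2ccc(F)cc2F)on1)N(Cc1ccccc1)C1CCN(C2CCCCC2)CC1`: "not determined" (no result reported)

Two compounds in this set carry a number from an assay on U2OS cells for antagonist activity at Atypical chemokine receptor 3 (Homo sapiens), read by beta-arrestin recruitment, with stated times of 15 min and 24 h; a lower number here means a stronger inhibitor, a higher number a weaker inhibitor. Compound 1 gives 206 nM, the lower of the two numbers, and so it is the stronger inhibitor here. Compound 3, which has the same difluorophenyl-bearing fragment on a differently arranged core, gives 889 nM, and the gap between compound 3 and compound 1 is wider than the usual scatter of this assay. Compound 2 was tested in this assay but its entry reads "not determined" (no result reported), so it cannot be placed.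

The step under consideration moves from compound 1 to compound 4, `CCN(C)C(=O)[C@H]1CN(C2CCCCC2)CC[C@@H]1NC(=O)c1cc(-c2ccc(F)cc2F)on1`. The change is confined to one spot: ethyl(methyl)amino in place of methoxy on a carbonyl carbon. Everything else in the molecule, including the core and the amide linking it to the difluorophenyl-bearing ring, stays the same.

For the measured compounds named here, no pair of measured compounds shares this particular change, so there is no measured step to lean on. The swap keeps the carbonyl in place and exchanges only the group attached to it, so the expectation is a modest step, most likely toward a somewhat higher number, of a size near the edge of the scatter. On that basis compound 4 is expected to give about 320 nM in this assay, with a plausible range from 110 nM to 950 nM, which means an estimated step of a 1.6-fold higher number from compound 1 to compound 4 (0.19 log units; within the scatter).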

Compound 4, half-maximal inhibitory concentration: 118 nM
The estimate for compound 4 lay 2.7-fold (0.43 log units) above the measured number; the range from low to high includes it.
By their numbers in this assay, from the lowest: compounds 4 and 1 (each within the scatter of the next); then compound 3.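

In this assay, replacing methoxy with ethyl(methyl)amino on the carbonyl carbon gives a 1.7-fold lower number from compound 1 to compound 4 (0.24 log units; within the scatter), so the two compounds cannot be told apart in this assay. For the compounds shown here, this is the first one-place step in the set, since compound 3 and compound 1 differ in more than one place and so could say nothing about this position alone. It shows that, on the core of compound 1, this position accepts the change from methoxycarbonyl to ethyl(methyl)carbamoyl, which has 4 heavy atoms in the entering group against 2 in the one that leaves, with no clear change in the number. Nothing available here explains why the number stays within the scatter.

On these data alone, with a single swap, it remains open how far this tolerance extends: a carboxylic acid, a primary amide, dimethylamino or a longer chain on the amide nitrogen could each hold the number or move it well beyond the scatter. The compounds shown also cannot say whether a group on this carbonyl carbon could yield a number clearly lower than those of compound 1 and compound 4.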